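The source may hold more compounds than are shown below. What is called first, only, known or untested is meant among the compounds shown, and "the series" means these compounds.

Compound 3, whose structure is `O=C(CSc1ncccn1)N/N=c1/scc(-c2ccc(F)cc2)n1-c1ccccc1`, gives 55.5% in a functional assay on C6 cells (Rattus norvegicus) for cytotoxicity, read by MTT assay, with a stated time of 24 h, tested at 50 ug/mL; on this read-out higher numbers stand for a weaker effect at the one concentration tested and lower numbers for a stronger effect. Compound 1, with the structure `Cc1nnc(SCC(=O)N/N=c2/scc(-c3ccc(F)cc3)n2-c2ccccc2)s1`, differs from it in one spot: 5-methyl-1,3,4-thiadiazol-2-yl in place of pyrimidin-2-yl on a sulfur. In this assay compound 1 gives 37.4%. That single swap brings a number 18.1 percentage points lower from compound 3 to compound 1 (beyond the scatter), so the move to the 5-methyl-1,3,4-thiadiazol-2-yl ring made the cells suffer more at the concentration tested.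

Compound 2, drawn as `Cc1ccc(-c2cs/c(=N/NC(=O)CSc3ncccn3)n2-c2ccccc2)cc1`, shares the core of compound 3 but carries methyl in place of fluoro on an aromatic carbon. In this assay compound 2 gives 64.4%, and the pair shows a number 8.9 percentage points lower from compound 2 to compound 3 (within the scatter), so the two cannot be told apart on this read-out.

Compound 4, `Cc1ccc(-c2cs/c(=N/NC(=O)CSc3nnc(C)s3)n2-c2ccccc2)cc1`, has not yet been tested. It stands to compound 2 exactly as compound 1 stands to compound 3: 5-methyl-1,3,4-thiadiazol-2-yl in place of pyrimidin-2-yl on a sulfur, and the place is the same, a sulfur whose other neighbours are a saturated chain carbon. Since that same change is already seen once, a step of a number 18.4 percentage points lower from compound 2 to compound 4 (beyond the scatter) is expected from compound 2 to compound 4, because a number 18.1 percentage points lower from compound 3 to compound 1 (beyond the scatter) was what the swap gave before. The expected value for compound 4 in this assay is therefore 46%, with a likely range from 32% to 60%.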

Compound 4, a percentage reported as activity, at one concentration (the size of the read-out at that concentration, not a potency): 40.6%
The estimate for compound 4 lay 5.4 percentage points above the measured number; the range from low to high includes it.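

In this assay, the swap to 5-methyl-1,3,4-thiadiazol-2-yl on the sulfur gives a clear step on the methyl-bearing core too, with a number 23.8 percentage points lower from compound 2 to compound 4 (beyond the scatter), and its size matches the step on the fluoro-bearing core: the same change on two cores in this assay, a number 18.1 percentage points lower (beyond the scatter) from compound 3 to compound 1 and a number 23.8 percentage points lower (beyond the scatter) from compound 2 to compound 4, 5.7 percentage points apart, within the scatter of two such steps. Methyl in place of fluoro on an aromatic carbon stays within the scatter on the thiadiazole side, with a number 3.2 percentage points higher from compound 1 to compound 4 (within the scatter), and that change also reads alike in both settings: the same change on two cores in this assay, a number 8.9 percentage points lower (within the scatter) from compound 2 to compound 3 and a number 3.2 percentage points lower (within the scatter) from compound 4 to compound 1, 5.7 percentage points apart, within the scatter of two such steps. This shows that the swap carried over between these two closely related cores, but two pairs at a single concentration do not show that it would hold on other cores, and they do not explain why the number falls.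

The compounds shown leave open how the swap behaves with other groups on that aromatic carbon, such as chloro, methoxy or an amine. They also leave open whether a chain longer than the one carrying the sulfur would keep the same step.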